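Swapping isobutyl for 2-methoxyethyl on the aromatic nitrogen

The source may hold more compounds than are shown below. What is called first, only, known or untested is meant among the compounds shown, and "the series" means these compounds.

In a functional assay on HT-29 cells (Homo sapiens) for inhibition, read by luminescence and CellTiter-Glo, with a stated time of 24 h (on this read-out higher numbers stand for an effect only at larger amounts of compound and lower numbers for an effect already at smaller amounts), compound 1 `CCn1nc(C(=O)N[C@H]2COc3ccccc3N(C)C2=S)nc1Cc1ccccc1` gives 17 nM, compound 2 `CC(C)n1nc(C(=O)N[C@H]2COc3ccccc3N(C)C2=S)nc1Cc1ccccc1` gives 360 nM, and compound 3 `CC(C)Cn1nc(C(=O)N[C@H]2COc3ccccc3N(C)C2=S)nc1Cc1ccccc1` gives 1230 nM, the highest number of the three. Compound 4 `COCCn1nc(C(=O)N[C@H]2COc3ccccc3N(C)C2=S)nc1Cc1ccccc1` has methoxymethyl in place of isopropyl on a saturated chain carbon bound to an aromatic nitrogen, which also reads as isobutyl to 2-methoxyethyl: methoxymethyl in place of isopropyl on a saturated chain carbon bound to an aromatic nitrogen. Three measured steps change this same chain: a 21-fold higher number from compound 1 to compound 2 (1.33 log units; beyond the scatter), a 72-fold higher number from compound 1 to compound 3 (1.86 log units; beyond the scatter) and a 3.4-fold higher number from compound 2 to compound 3 (0.53 log units; beyond the scatter). None of them brings in an oxygen, so they guide only loosely. With compound 3 at the top at 1230 nM, a modest move towards a lower number is expected in this assay. The expected change is a 2.5-fold lower number from compound 3 to compound 4 (0.39 log units; beyond the scatter). Compound 4 is estimated at about 500 nM, with an expected range from 100 nM to 2000 nM.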

Compound 4, half-maximal effective concentration: 566 nM
The estimate for compound 4 lay 1.1-fold (0.05 log units) below the measured number; the measured number falls inside the stated range.
By their numbers in this assay, from the lowest: compound 1; then compounds 2 and 4 (each within the scatter of the next); then compound 3.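

In this assay, among the compounds shown here, 2-methoxyethyl brings an oxygen into the group on the aromatic nitrogen for the first time, and exchanging isobutyl for it gives a 2.2-fold lower number from compound 3 to compound 4 (0.34 log units; beyond the scatter). Set against isopropyl, the same group gives a 1.6-fold higher number from compound 2 to compound 4 (0.20 log units; within the scatter), so these two cannot be ordered. Adding methoxy to the chain of the best compound here still leaves a 33-fold higher number from compound 1 to compound 4 (1.52 log units; beyond the scatter), so this oxygen does not restore the low number.

Nothing measured here says why the oxygen changes the number. From the compounds shown here alone, whether a 3-methoxypropyl or 2-aminoethyl group on the aromatic nitrogen would match 2-methoxyethyl remains open.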